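Compound 1 to compound 4: replacing the carboxyethyl pyrazole

The compounds below may be only part of what the source reports. "The series", "measured", "known", "first", "only" and "open" are said of these compounds alone.

compound 1 `COc1ncc(-c2ccc3ncnc(Nc4cnn(CCC(=O)O)c4)c3c2)cc1NS(C)(=O)=O` gives 3840 nM
compound 2 `COc1ncc(-c2ccc3ncnc(Nc4cnn(CCCO)c4)c3c2)cc1NS(=O)(=O)c1ccc(F)cc1F` gives 4830 nM
compound 3 `COc1ncc(-c2ccc3ncnc(Nc4ccc(OCCO)nc4)c3c2)cc1NS(=O)(=O)c1ccc(F)cc1F` gives 4120 nM

All three values come from a functional assay on A549 cells (Homo sapiens) for antiproliferative activity, read by sulforhodamine B assay, with a stated time of 72 h (a higher number here means a weaker inhibitor, a lower number a stronger inhibitor), and compound 1 stands level with compound 2 and compound 3, within the scatter of both. Compound 4 `COc1ncc(-c2ccc3ncnc(Nc4ccc(OCCO)cc4)c3c2)cc1NS(C)(=O)=O` has yet to be measured. The change from compound 1 is 4-(2-hydroxyethoxy)phenyl in place of 1-(2-carboxyethyl)-1H-pyrazol-4-yl on a nitrogen on an aromatic ring and in words it puts 4-(2-hydroxyethoxy)phenyl in place of 1-(2-carboxyethyl)-1H-pyrazol-4-yl on a nitrogen on an aromatic ring.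

Going by the values given here, one measured step bears on this place. Putting 6-(2-hydroxyethoxy)pyridin-3-yl in place of 1-(3-hydroxypropyl)-1H-pyrazol-4-yl gave a 1.2-fold lower number from compound 2 to compound 3 (0.07 log units; within the scatter) and thus no change beyond the scatter. Among the compounds with values here, that step carries a different sulfonyl substituent from compound 1, and no measured pair shows 1-(2-carboxyethyl)-1H-pyrazol-4-yl leaving, so the range stays wide.

The expected change in this assay is no step beyond the scatter, estimated as a 1.3-fold lower number from compound 1 to compound 4 (0.11 log units; within the scatter) at the middle of the range. For compound 4 the estimated value is 3000 nM with an expected range of 800 nM to 8000 nM for this measurement.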

Compound 4, half-maximal inhibitory concentration: 5200 nM
Estimate against measurement, compound 4: 1.7-fold (0.24 log units) below, within the range that was stated.
By their numbers in this assay, from the lowest: compounds 1, 3, 2 and 4 (each within the scatter of the next).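

In this assay the change gives a 1.4-fold higher number from compound 1 to compound 4 (0.13 log units; within the scatter), the first step shown in which 1-(2-carboxyethyl)-1H-pyrazol-4-yl leaves. At this place, on a nitrogen on an aromatic ring, a six-membered aromatic ring of carbon only with a 2-hydroxyethoxy chain therefore reads level with the five-membered aromatic ring carrying the carboxyethyl chain, with the sulfonyl substituent of compound 1 kept. The flat reading extends what the step from compound 2 to compound 3 showed for a different sulfonyl substituent, and no evidence on the compounds accounts for it.

From the compounds shown here alone, whether an amine such as a piperazine, or a longer chain, on the 4-position of the phenyl ring would move the number beyond the scatter stays open. Also open, going by these compounds, is whether the 2,4-difluorophenyl sulfonyl group of compound 3 would read the same with 4-(2-hydroxyethoxy)phenyl at this place.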